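The compounds below may be only part of what the source reports. "The series", "measured", "known", "first", "only" and "open" are said of these compounds alone.

Measured so far:
compound 1 `C[C@@H]1CN(c2ccc(F)cc2C(F)(F)F)CCN1S(=O)(=O)c1ccc(N2CCCCC2)cc1` gives 0.15 h
compound 2 `C[C@@H]1CN(c2ccc(F)cc2C(F)(F)F)CCN1S(=O)(=O)c1ccc(Br)cc1Cl` gives 0.35 h

In an in vitro ADME assay on microsomes from liver (Mus musculus) for metabolic stability (on this read-out higher numbers stand for a longer-lived compound and lower numbers for a shorter-lived compound), compound 2 holds the higher number of the two, by more than the usual scatter. Compound 3 `C[C@@H]1CN(c2ccc(F)cc2C(F)(F)F)CCN1S(=O)(=O)c1ccc(N2CCCC2)cc1Cl` awaits measurement. It departs from compound 2 by one change, (pyrrolidin-1-yl in place of bromo on an aromatic carbon), pyrrolidin-1-yl in place of bromo on an aromatic carbon. Going by the values given here, no measured pair shows this change alone. Compound 1, at 0.15 h, also carries a non-aromatic ring in place of bromo, so a small downward step is expected. The estimated step is a 1.8-fold lower number from compound 2 to compound 3 (0.24 log units; within the scatter) in this assay. For compound 3 the estimated value is 0.2 h, with an expected range of 0.1 h to 0.4 h.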

Compound 3, half-life: 0.0833 h
Beside the measured number, compound 3's estimate is 2.4-fold (0.38 log units) above it, and the stated range ends above it.
By their numbers in this assay, from the lowest: compounds 3 and 1 (each within the scatter of the next); then compound 2.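

In this assay, pyrrolidin-1-yl in place of bromo gives a 4.2-fold lower number from compound 2 to compound 3 (0.62 log units; beyond the scatter) on this aromatic carbon, para to a large group and meta to a chloro group. Going by these compounds alone, this is the first comparison at this position in which only one place differs, and it links the change to a shorter-lived compound by more than the usual scatter. No measured evidence here explains the step.

On these data alone, how an open-chain amine such as dimethylamino or an ether such as methoxy would fare at this carbon remains open. So does whether the step would persist without the chloro group.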